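Swapping a Dichlorobenzyl for a Methoxybenzyl Amine

This account rests on a few compounds, and the source may have more. Where it says the series, first, only, none or still open, it means among the compounds named here.

Measured compounds:
compound 1, `Nc1cc(N)c2nc(-c3ccccc3)c(Oc3ccc(Cl)c(Cl)c3)nc2c1`: 83200 nM
compound 2, `Nc1cc(N)c2nc(-c3ccccc3)c(NCc3ccc(Cl)c(Cl)c3)nc2c1`: 34700 nM
compound 3, `CCOC(=O)[C@H](CCC(=O)O)NC(=O)c1ccc(Oc2nc3cc(N)cc(N)c3nc2-c2ccccc2)cc1`: < 100000 nM (a limit)

In a functional assay on SK-MEL-5 cells (Homo sapiens) for inhibition, read by sulforhodamine B assay, with a stated time of 48 h (a lower number here means that less compound is tolerated, a higher number that more compound is tolerated), compound 1 gives 83200 nM and compound 2 gives 34700 nM. For compound 3 the reading < 100000 nM is a limit of this assay, not a number (the limit of < 100000 nM in this assay, at which 1 of the 3 values shown sits). Compound 2 thus has the lowest of the two numbers; compound 1 sits at a higher number, and that gap lies beyond the usual scatter.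

Compound 4, `COc1ccc(CNc2nc3cc(N)cc(N)c3nc2-c2ccccc2)cc1`, has not yet been measured in this assay. It differs from compound 2 in one place: 4-methoxyphenyl in place of 3,4-dichlorophenyl on a saturated chain carbon bound to a nitrogen on an aromatic ring. For the measured compounds named here, no measured pair shows this kind of change, so there is no step to lean on. The expectation is a modest upward move, roughly at the edge of the scatter, estimated as a 1.6-fold higher number from compound 2 to compound 4 (0.20 log units; within the scatter). Compound 4 is therefore expected to give about 55000 nM, in a range from 18000 nM to 150000 nM.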

Compound 4, concentration lethal to 50% of the cells: 56200 nM
Compound 4: middle estimate off by 1.0-fold (0.01 log units), on the low side; low and high end bracket the measured number.
By their numbers in this assay, from the lowest: compounds 2, 4 and 1 (each within the scatter of the next, the first and the last beyond it).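

Replacing 3,4-dichlorophenyl with 4-methoxyphenyl on a saturated chain carbon bound to a nitrogen on an aromatic ring gives, in this assay, a 1.6-fold higher number from compound 2 to compound 4 (0.21 log units; within the scatter). Compound 2 and compound 4 therefore cannot be told apart in this read-out, even though the chlorine atoms of one are exchanged for the methoxy group of the other, which adds a hydrogen-bond acceptor. Nothing else measured here speaks to why the two read alike.

The compounds shown leave open whether the same holds for other groups in this place, such as a phenyl ring carrying an amine or a carboxylic acid. They also cannot separate losing the chlorine atoms from gaining the methoxy group, which would take a plain phenyl ring at this place.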